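The source may hold more compounds than are shown below. What is called first, only, known or untested is meant among the compounds shown, and "the series" means these compounds.

Measured compounds:
compound 1 `CCCSc1nc(N/N=C(\C)c2ccccc2O)c2nnn(Cc3ccc(O)cc3)c2n1`, 15900 nM
compound 2 `CCCSc1nc(N/N=C(\C)c2ccccc2O)c2nnn(Cc3ccc(F)cc3)c2n1`, 21900 nM
compound 3 `CCCSc1nc(N/N=C(\C)c2ccccc2O)c2nnn(Cc3cccc(Cl)c3)c2n1`, 13000 nM

In a functional assay on ECa-109 cells (Homo sapiens) for antiproliferative activity, read by MTT assay, with a stated time of 72 h (on this read-out lower numbers stand for stronger inhibition and higher numbers for weaker inhibition), compound 3 gives the lowest of the three numbers, but its separation from the others is small: the step of a 1.2-fold lower number from compound 1 to compound 3 (0.09 log units; within the scatter) and the step of a 1.7-fold lower number from compound 2 to compound 3 (0.23 log units; within the scatter) both lie within the scatter, as does the step of a 1.4-fold higher number from compound 1 to compound 2 (0.14 log units; within the scatter) between the other two. Compound 4 `CCCSc1nc(N/N=C(\C)c2ccccc2O)c2nnn(Cc3ccc(Br)cc3)c2n1` differs from compound 3 by 4-bromophenyl in place of 3-chlorophenyl on a saturated chain carbon bound to an aromatic nitrogen. All three measured steps bear on this change, since each of them also exchanges the group on the benzyl ring that sits on the aromatic nitrogen of the shared core, and none of them moved the number beyond the scatter. On that basis no step beyond the scatter is expected in this assay for this exchange either. The estimate for compound 4 is 14000 nM, with a range from 6000 nM to 33000 nM. This corresponds to an expected step of a 1.1-fold higher number from compound 3 to compound 4 (0.03 log units; within the scatter).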

Compound 4, half-maximal inhibitory concentration: 36100 nM
The estimate for compound 4 lay 2.6-fold (0.41 log units) below the measured number; the measured number lies above the stated range.
By their numbers in this assay, from the lowest: compounds 3, 1, 2 and 4 (each within the scatter of the next, the first and the last beyond it).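

In this assay, going by these compounds alone, the exchange of 3-chlorobenzyl for 4-bromobenzyl is the first change at this place, on a saturated chain carbon bound to an aromatic nitrogen, to go beyond the scatter, with a 2.8-fold higher number from compound 3 to compound 4 (0.44 log units; beyond the scatter), and bromo in place of hydroxy also goes beyond it, with a 2.3-fold higher number from compound 1 to compound 4 (0.36 log units; beyond the scatter). Both steps are modest, while bromo in place of fluoro stays within the scatter, with a 1.6-fold higher number from compound 2 to compound 4 (0.22 log units; within the scatter), so the benzyl substituent does affect the number here, but not every exchange at this place does. Nothing available accounts for this difference.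

The step from 3-chlorobenzyl to 4-bromobenzyl changes both the halogen and where it sits on the ring, and the compounds shown do not separate these two changes. On these data alone, how an amine or a carboxylic acid on this ring would read also remains open.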